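A few compounds are considered here, and "the series" means these few. Any claim that something is new, unique, unknown or untested is made for them only; others in the source may bear on it.

Measured so far:
compound 1, `Cc1ccc(C(O)CCN2CC=C(Cc3ccccc3)CC2)cc1`: 30%
compound 2, `COc1ccc2cc(C(O)CCN3CCC(O)(Cc4ccccc4)CC3)ccc2c1Cl`: 73%
compound 3, `OC(CCN1CC=C(Cc2ccccc2)CC1)c1ccc2c(c1)CCO2`: 49%

Notes on the series. Three compounds have been run in an assay on CHO cells for inhibition of sodium-dependent dopamine transporter (Homo sapiens), read by scintillation counting, with a stated time of 10 min, tested at 10 uM; a lower number here means less inhibition, a higher number more inhibition at the concentration tested (going by the name of the read-out). In this assay compound 1 gives 30%, the lowest of the three numbers. The nearest neighbour is compound 3, whose value of 49% sits above compound 1 by a margin beyond the usual scatter; compound 2 is furthest away, its 73% standing well beyond the scatter above compound 1. Going by the values given here, no two of the measured compounds differ in a single place, so no single-change step is available within the set; compounds 2 and 3 both differ from compound 1 in more than one respect.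

Next in line is compound 4, `OC(CCN1CC=C(Cc2ccccc2)CC1)c1ccc(F)cc1F`, not yet measured in this assay. Relative to compound 1 the change is 2,4-difluorophenyl in place of 4-methylphenyl on a saturated chain carbon bound to an oxygen on a saturated carbon and a saturated chain carbon. The shared core carrying the alcohol and the unsaturated ring is kept.

Among the compounds with values here, with no measured single step to lean on, the expected step from compound 1 to compound 4 is a number 8 percentage points higher from compound 1 to compound 4 (within the scatter), a small rise that may well stay within the scatter. Compound 4 is expected to give 38% in this assay, with a range from 20% to 58%.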

Compound 4, a percentage reported as inhibition, at one concentration (the size of the read-out at that concentration, not a potency): 66%
For compound 4 the middle estimate is 28 percentage points below the measured one; the whole stated range lies below it.
By their numbers in this assay, from the lowest: compound 1; then compound 3; then compounds 4 and 2 (each within the scatter of the next).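

Going by these compounds alone, this is the first single-change step: in this assay, 2,4-difluorophenyl in place of 4-methylphenyl gives a number 36 percentage points higher from compound 1 to compound 4 (beyond the scatter). The group on the saturated chain carbon bound to an oxygen on a saturated carbon and a saturated chain carbon is therefore a place where the read-out can move substantially, with the alcohol, the unsaturated ring and the rest of the shared core unchanged. No available information bears on why this exchange has an effect of this size.

From the compounds shown here alone, this one step cannot separate the entry of the two fluorines from the departure of the methyl group, so it remains open whether a phenyl group carrying a single fluorine, a nitrile or a trifluoromethyl group would give a similar number. Also open, going by these compounds, is whether the step would hold with an amine in place of the alcohol or with a longer chain between the alcohol-bearing carbon and the ring nitrogen.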